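Swapping a Thiophene Amide for an Ethylphenyl Amide

This account rests on a few compounds, and the source may have more. Where it says the series, first, only, none or still open, it means among the compounds named here.

Three compounds have been measured so far:
compound 1, `Cc1cccc(Cn2c(CN3CCN(C(=O)c4cccs4)CC3)nc3ccccc32)c1`: 60.8%
compound 2, `CC(C)CCn1c(OC2CCN(C(=O)c3ccco3)CC2)nc2ccccc21`: 30.8%
compound 3, `O=C(C1CC1)N1CCN(Cc2nc3ccccc3n2CC2CC2)CC1`: 21.2%

In an assay on isolated protein for inhibition of aldehyde dehydrogenase 1A1 (Homo sapiens), read by spectrophotometry, tested at 10 uM (a higher number here means more inhibition at the concentration tested (going by the name of the read-out), a lower number less inhibition), compound 1 gives the highest of these three numbers; compound 2 and compound 3 each lie lower by a gap beyond the usual scatter. Compound 4, `CCc1ccc(C(=O)N2CCN(Cc3nc4ccccc4n3Cc3cccc(C)c3)CC2)cc1`, keeps the whole skeleton of compound 1 and changes only the group on the carbonyl carbon: 4-ethylphenyl in place of thiophen-2-yl on a carbonyl carbon. Within the data shown here, no pair of measured compounds differs by this same change, so nothing measured directly shows its effect. Because compound 1 gives 60.8%, a step in either direction that stays within the scatter is expected, so compound 4 is estimated at 55% (30% to 80%), a change of a number 5.8 percentage points lower from compound 1 to compound 4 (within the scatter).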

Compound 4, a percentage reported as inhibition, at one concentration (the size of the read-out at that concentration, not a potency): 67%
Beside the measured number, compound 4's estimate is 12 percentage points below it; low and high end bracket the measured number.
By their numbers in this assay, from the lowest: compounds 3 and 2 (each within the scatter of the next); then compounds 1 and 4 (each within the scatter of the next).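

On the carbonyl carbon, 4-ethylphenyl in place of thiophen-2-yl gives a number 6.2 percentage points higher from compound 1 to compound 4 (within the scatter) in this assay. This position therefore accepts a larger, six-membered aromatic ring of carbon only, and in this pair the sulfur of the thiophen-2-yl group is not needed to keep the number within the scatter. Nothing at hand explains why the two numbers stay this close.

Among these compounds, still open is whether the ethyl group itself matters, since only this one pair shows the change. A phenyl ring carrying a carboxylic acid, an amine or a longer chain in its place could read differently.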